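The compounds below may be only part of what the source reports. "The series", "measured", "known", "first", "only" and "open" are said of these compounds alone.

The measured compounds:
- compound 1 `CC1CCC(=NNc2ccccc2)c2ncc(C(=O)O)c(=O)n21`: in a functional assay on the whole organism with Rattus norvegicus as the target (on this read-out lower numbers stand for an effect already at smaller amounts and higher numbers for an effect only at larger amounts of compound), compound 1 gives 0.6 umol/kg
- compound 2 `CC1CCC(=NNc2ccccn2)c2ncc(C(=O)O)c(=O)n21`: in this assay compound 2 gives 3.2 umol/kg

Compound 2 stands at the higher of the two numbers in this assay; its nearest neighbour is compound 1, and the step of a 5.3-fold higher number from compound 1 to compound 2 (0.73 log units; beyond the scatter) separates them. The next compound, compound 3 `CC1CCC(=NNc2cccnc2)c2ncc(C(=O)O)c(=O)n21`, has not yet been measured in this assay. It differs from compound 2 in one place: pyridin-3-yl in place of pyridin-2-yl on an amine nitrogen.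

Within the data shown here, only one measured step exists, a 5.3-fold higher number from compound 1 to compound 2 (0.73 log units; beyond the scatter), and it concerns a different change, from phenyl to pyridin-2-yl on the amine nitrogen. It shows that the group on this nitrogen can move the number in this assay by a modest amount, but it gives no direct guide to a shift of the ring nitrogen from pyridin-2-yl to pyridin-3-yl. Compound 3 is therefore expected to land close to compound 2, with a step of a 1.6-fold lower number from compound 2 to compound 3 (0.20 log units; within the scatter) that may lie within the scatter or somewhat toward compound 1. The estimate for compound 3 in this assay is 2 umol/kg, with a range from 0.6 umol/kg to 7 umol/kg.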

Compound 3, dose for 50% inhibition: 0.54 umol/kg
For compound 3 the middle estimate is 3.7-fold (0.57 log units) above the measured one; measured number outside the range, below it.
By their numbers in this assay, from the lowest: compounds 3 and 1 (each within the scatter of the next); then compound 2.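

In this assay, the place of the ring nitrogen matters in its own right: with the same atoms joined differently, the change to pyridin-3-yl gives a 5.9-fold lower number from compound 2 to compound 3 (0.77 log units; beyond the scatter) and thus reverses a step of about the same size as the only one known before. Pyridin-3-yl and phenyl on the amine nitrogen cannot be told apart here, with a 1.1-fold lower number from compound 1 to compound 3 (0.05 log units; within the scatter) as their step, so the rise seen earlier with pyridin-2-yl does not come with every ring nitrogen and, among these three compounds, is found only in compound 2. The data offer no measured explanation of why pyridin-2-yl stands apart from the other two groups.

From the compounds shown here alone, it remains open whether pyridin-4-yl would fall with pyridin-3-yl and phenyl or with pyridin-2-yl, and whether a pyrimidin-2-yl group, or a phenyl ring carrying a methoxy group or a chlorine, would hold the number or move it. Going by these compounds, the methyl group and the carboxylic acid are the same in all three compounds, so what an ethyl group or an amide in their places would do also stays open.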